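This account rests on a few compounds, and the source may have more. Where it says the series, first, only, none or still open, it means among the compounds named here.

Measured compounds:

Compound 1, `CC(C)(C)c1cn(C[C@H](O)[C@H]2OC(=O)C(OCc3ccccc3)=C2OCc2ccccc2)nn1`: 13300 nM
Compound 2, `O=C1O[C@H]([C@@H](O)Cn2cc(CNS(=O)(=O)c3ccc(F)cc3)nn2)C(OCc2ccccc2)=C1OCc1ccccc1`: 30 nM
Compound 3, `CCCCCc1ccc(-c2cn(C[C@H](O)[C@H]3OC(=O)C(OCc4ccccc4)=C3OCc3ccccc3)nn2)cc1`: a limit

In an ADME assay on HFF cells (Homo sapiens) for cytotoxicity, read by MTT assay, with a stated time of 72 h (a lower number here means a stronger inhibitor, a higher number a weaker inhibitor), compound 1 gives 13300 nM. Compound 2, which carries a sulfonamide-bearing side chain instead of the tert-butyl group, gives 30 nM in this assay. For compound 3 this assay reports only a limit, > 100000 nM, which is a boundary of the measurement and not a number (the limit of > 100000 nM in this assay, at which 1 of the 3 values shown sits). Among the numbers shown, compound 1 therefore stands highest, with compound 2 far below it.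

Compound 4, `O=C1O[C@H]([C@@H](O)Cn2cc(CNS(=O)(=O)c3ccc(Cl)cc3)nn2)C(OCc2ccccc2)=C1OCc1ccccc1`, has not yet been measured in this assay. Relative to compound 1 the change is (((4-chlorophenyl)sulfonyl)amino)methyl in place of tert-butyl on an aromatic carbon. The step that bears on this most directly is a 440-fold lower number from compound 1 to compound 2 (2.65 log units; beyond the scatter), since compound 2 differs from compound 4 only by fluorine in place of chlorine on the outer ring. The other measured steps, an at least 7.5-fold higher number from compound 1 to compound 3 (0.87 log units; beyond the scatter) and an at least 3300-fold higher number from compound 2 to compound 3 (3.52 log units; beyond the scatter), concern a different replacement and point the other way. A large lowering is therefore expected, of about a 330-fold lower number from compound 1 to compound 4 (2.52 log units; beyond the scatter), placing compound 4 near compound 2. The expected value for compound 4 in this assay is 40 nM, with a likely range from 10 nM to 160 nM.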

Compound 4, half-maximal inhibitory concentration: 20 nM
For compound 4 the middle estimate is 2.0-fold (0.30 log units) above the measured one; the range from low to high includes it.
By their numbers in this assay, from the lowest: compounds 4 and 2 (each within the scatter of the next); then compound 1. At a limit, above all of these: compound 3.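

In this assay, chloro in place of fluoro on an aromatic carbon gives a 1.5-fold lower number from compound 2 to compound 4 (0.18 log units; within the scatter), so the two halogens cannot be told apart here, and the large step away from tert-butyl now holds for a second sulfonamide side chain, as a 670-fold lower number from compound 1 to compound 4 (2.82 log units; beyond the scatter). The same side chain also stands far from the 4-pentylphenyl group, with an at least 5000-fold lower number from compound 3 to compound 4 (3.69 log units; beyond the scatter), which shows that what sits on this aromatic carbon of the five-membered ring can move the read-out a long way in either direction. That step can only be read as a minimum, as compound 3 has a limit and not a number: the limit of > 100000 nM in this assay, at which 1 of the 4 values shown sits.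

The compounds shown leave open which part of the side chain goes with the large step: the sulfonyl group, the outer aromatic ring or the halogen on it. A plain aminomethyl group, a methylsulfonylamino side chain or an unsubstituted phenylsulfonyl side chain at the same place would help separate these parts, and a bromo or methoxy group in place of the halogen would test how far the insensitivity seen with compound 2 and compound 4 extends.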